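Swapping the bromo side chain on the shared core

A few compounds are considered here, and "the series" means these few. Any claim that something is new, unique, unknown or untested is made for them only; others in the source may bear on it.

Values in a functional assay on KYSE-450 cells (Homo sapiens) for inhibition, read by MTT assay, with a stated time of 48 h; on this read-out higher numbers stand for weaker inhibition and lower numbers for stronger inhibition:
- Compound 1 `CCCCC(=O)N(Cc1ccc(OC)c(O)c1)c1cc(OC)c(OC)c(OC)c1`: 300 nM
- Compound 2 `COc1ccc(CN(C(=O)CO)c2cc(OC)c(OC)c(OC)c2)cc1O`: 370 nM
- Compound 3 `COc1ccc(CN(C(=O)/C=C/CBr)c2cc(OC)c(OC)c(OC)c2)cc1O`: 100 nM

In this assay, compound 3 gives the lowest number of the three, 100 nM. Two measured steps reach it, both modest: a 3.0-fold lower number from compound 1 to compound 3 (0.48 log units; beyond the scatter) and a 3.7-fold lower number from compound 2 to compound 3 (0.57 log units; beyond the scatter). The remaining step, a 1.2-fold higher number from compound 1 to compound 2 (0.09 log units; within the scatter), shows that those two starting points do not separate.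

Compound 4 `COc1ccc(CN(C(=O)CBr)c2cc(OC)c(OC)c(OC)c2)cc1O` changes the same place again: bromomethyl in place of 3-bromoprop-1-en-1-yl on a carbonyl carbon. Bromomethyl stands in place of 3-bromoprop-1-en-1-yl on a carbonyl carbon, so the bromine stays and the double bond goes. The measured compounds cannot show which of these two features goes with the lower number. The modest steps above therefore set the likely outer size of any loss, and a step back towards compound 1 remains possible. No change beyond the scatter is the most likely outcome. The expected step is a 1.2-fold higher number from compound 3 to compound 4 (0.08 log units; within the scatter). For compound 4 the estimate is 120 nM, with an expected range from 40 nM to 350 nM.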

Compound 4, half-maximal inhibitory concentration: 120 nM
Beside the measured number, compound 4's estimate shows no gap at the digits printed; the range from low to high includes it.
By their numbers in this assay, from the lowest: compounds 3 and 4 (each within the scatter of the next); then compounds 1 and 2 (each within the scatter of the next).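

Replacing 3-bromoprop-1-en-1-yl with bromomethyl on the carbonyl carbon removes the double bond and shortens the chain, yet gives only a 1.2-fold higher number from compound 3 to compound 4 (0.08 log units; within the scatter) in this assay. So, at this position, neither the double bond nor the longer chain is needed for a low number, and the saturated chain carbon bound to the carbonyl carbon can be compared directly: bromo gives a 3.1-fold lower number from compound 2 to compound 4 (0.49 log units; beyond the scatter) and a 2.5-fold lower number from compound 1 to compound 4 (0.40 log units; beyond the scatter). Among these four compounds, the two carrying bromine have the lower numbers and none goes against that pattern, but nothing shown here explains the link.

Going by these compounds, it remains open whether bromine itself matters, or whether another group on that chain carbon, such as chloro or an amine, would give a similar number. A carboxylic acid at this position also remains untested in the compounds shown.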